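A few compounds are considered here, and "the series" means these few. Any claim that something is new, unique, unknown or untested is made for them only; others in the source may bear on it.

In a functional assay on HCT-116 cells (Homo sapiens) for antiproliferative activity, read by WST assay, with a stated time of 72 h (a lower number here means a stronger inhibitor of growth, a higher number a weaker inhibitor of growth), three compounds sharing one core have been measured: compound 1 (`N#Cc1ccc(CN[C@H]2[C@@H]3CN(c4ncc(C(=O)NO)cn4)C[C@@H]32)cc1`) gives 270 nM, compound 2 (`O=C(NO)c1cnc(N2C[C@@H]3[C@H](C2)[C@H]3NCc2ccccc2)nc1`) gives 120 nM and compound 3 (`O=C(NO)c1cnc(N2C[C@@H]3[C@H](C2)[C@H]3NCc2ccc(C(F)(F)F)cc2)nc1`) gives 700 nM. Compound 3 therefore has the highest number of the three, making it the weakest growth inhibitor so far. Compound 4 (`O=C(NO)c1cnc(N2C[C@@H]3[C@H](C2)[C@H]3NCc2ccc(OC(F)(F)F)cc2)nc1`) has trifluoromethoxy in place of trifluoromethyl on an aromatic carbon, and the swap counts as trifluoromethoxy in place of trifluoromethyl on an aromatic carbon.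

Within the data shown here, three measured steps concern this same place on the ring: a 2.3-fold lower number from compound 1 to compound 2 (0.35 log units; beyond the scatter), a 2.6-fold higher number from compound 1 to compound 3 (0.41 log units; beyond the scatter) and a 5.8-fold higher number from compound 2 to compound 3 (0.77 log units; beyond the scatter). They show that changes here can move the number, with the largest step coming when trifluoromethyl replaces hydrogen. None of them involves trifluoromethoxy, so the direction of the new step remains uncertain. The entering group still carries the carbon and fluorines of the group it replaces, so only a small shift is expected. The expected step is a 1.2-fold lower number from compound 3 to compound 4 (0.07 log units; within the scatter), which would not go beyond the scatter. Compound 4 is estimated at 600 nM, with an expected range from 250 nM to 1400 nM.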

Compound 4, concentration for 50% growth inhibition: 120 nM
Compound 4: middle estimate off by 5.0-fold (0.70 log units), on the high side; the measured number lies below the stated range.
By their numbers in this assay, from the lowest: compounds 2 and 4 (each within the scatter of the next); then compound 1; then compound 3.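

At this place on the ring, inserting an oxygen into the group matters far more than the shared carbon and three fluorines might suggest in this assay (a 5.8-fold lower number from compound 3 to compound 4 (0.77 log units; beyond the scatter)). Compounds 1, 2 and 3 alone hinted that replacing hydrogen here raises the number, but compound 4 goes against that pattern, with trifluoromethoxy giving no change at the digits printed from compound 2 to compound 4 (within the scatter) and, against the nitrile, a 2.3-fold lower number from compound 1 to compound 4 (0.35 log units; beyond the scatter); a large group at this place therefore need not cost activity. Nothing available here explains what the oxygen does.

Still open, going by these compounds, is how methoxy, which keeps the oxygen without the fluorines, would compare with trifluoromethoxy. An amine, a carboxylic acid or a longer chain such as ethoxy at this place would also show how widely this position tolerates change.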